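The source may hold more compounds than are shown below. What is called first, only, known or untested is meant among the compounds shown, and "the series" means these compounds.

Compound 1 `CCOC(=O)C1=Cc2ccccc2OC1(OCc1cn(CC(=O)Nc2ccc(OC)cc2)nn1)C(F)(F)F` belongs to a small set built on one shared core, in which only the group on the aromatic nitrogen of the five-membered ring changes. In a functional assay on A549 cells (Homo sapiens) for inhibition, read by MTT assay, with a stated time of 24 h (on this read-out lower numbers stand for stronger inhibition and higher numbers for weaker inhibition), compound 1 gives 29400 nM. Within the data shown here, the only other compound measured so far, compound 2 `CCOC(=O)C1=Cc2ccccc2OC1(OCc1cc(-c2ccc(F)cc2)no1)C(F)(F)F`, gives 35500 nM in this assay; the two numbers sit within the usual scatter of each other, so neither compound stands apart from the other, and compound 1 cannot be called stronger or weaker.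

Compound 3 `CCOC(=O)C1=Cc2ccccc2OC1(OCc1cn(-c2ccc(C)cc2)nn1)C(F)(F)F` has not been measured yet. Compared with compound 1 the change is 4-methylphenyl in place of ((4-methoxyphenyl)carbamoyl)methyl on an aromatic nitrogen. Among the measured compounds shown here, no measured pair shows what such a swap does on this core, so the step from compound 1 to compound 3 is expected to be a 1.0-fold higher number from compound 1 to compound 3 (0.01 log units; within the scatter), that is, no change beyond the scatter. Compound 3 is therefore expected to give about 30000 nM in this assay, with a likely range from 12000 nM to 75000 nM.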

Compound 3, half-maximal inhibitory concentration: 19700 nM
The estimate for compound 3 lay 1.5-fold (0.18 log units) above the measured number, within the range that was stated.
By their numbers in this assay, from the lowest: compounds 3, 1 and 2 (each within the scatter of the next).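

On the aromatic nitrogen of the five-membered ring, the swap to 4-methylphenyl in this assay gives a 1.5-fold lower number from compound 1 to compound 3 (0.17 log units; within the scatter), so this pair shows no change that can be told apart from the scatter. The group that leaves carries a hydrogen-bond donor and hydrogen-bond acceptors, and the group that enters carries neither, yet both hold a six-membered aromatic ring of carbon, so on this one pair, losing the donor and acceptors while keeping that ring does not move the number beyond the scatter. Nothing at hand explains this outcome.

On these data alone, whether any group at this position can move the number beyond the scatter remains open. A simple amine, a carboxylic acid or a longer carbon chain on this nitrogen, or an unsubstituted phenyl, could test that.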